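The source may hold more compounds than are shown below. What is called first, only, known or untested is meant among the compounds shown, and "the series" means these compounds.

Compound 1 `CC(O)(CSc1cccc(OC(F)(F)F)c1)C(=O)Nc1ccc(S(F)(F)(F)(F)F)cc1`: 13800 nM
Compound 2 `CC(O)(CS(=O)(=O)c1ccc(S(F)(F)(F)(F)F)cc1)C(=O)Nc1ccc(S(F)(F)(F)(F)F)cc1`: 15700 nM
Compound 3 `CC(O)(CS(=O)(=O)c1ccc(C(F)(F)F)cc1)C(=O)Nc1ccc(S(F)(F)(F)(F)F)cc1`: 27700 nM

These three values come from a functional assay on VCaP cells (Homo sapiens) for antiproliferative activity, read by propidium iodide staining, with a stated time of 96 h; a lower number here means a stronger inhibitor, a higher number a weaker inhibitor. All are close together: compound 3, at 27700 nM, lies within the usual scatter of both compound 1 and compound 2, so the numbers do not separate them.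

The next compound is compound 4 `CC(O)(CS(=O)(=O)c1ccccc1C(F)(F)F)C(=O)Nc1ccc(S(F)(F)(F)(F)F)cc1`. It carries 2-(trifluoromethyl)phenyl in place of 4-(trifluoromethyl)phenyl on a sulfonyl sulfur. The two compounds have the same atoms, joined differently.

Among the measured compounds shown here, no measured pair shows what moving the trifluoromethyl group does. The nearest evidence is a different change, the exchange of a group on an aromatic carbon, which gave a 1.8-fold higher number from compound 2 to compound 3 (0.25 log units; within the scatter). That step stays within the scatter, so it offers only weak guidance, and no step beyond the scatter is expected in this assay.

The estimate amounts to an expected 1.2-fold lower number from compound 3 to compound 4 (0.06 log units; within the scatter).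

For compound 4 the estimated value is 24000 nM, with an expected range of 11000 nM to 50000 nM.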

Compound 4, half-maximal inhibitory concentration: 23800 nM
Beside the measured number, compound 4's estimate is 1.0-fold (0.00 log units) above it; low and high end bracket the measured number.
By their numbers in this assay, from the lowest: compounds 1, 2, 4 and 3 (each within the scatter of the next).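

Moving the trifluoromethyl group, with 2-(trifluoromethyl)phenyl in place of 4-(trifluoromethyl)phenyl on a sulfonyl sulfur, gives a 1.2-fold lower number from compound 3 to compound 4 (0.07 log units; within the scatter) in this assay. The earlier compounds shown here offered no pair of this kind, and this one shows that these two placements of the same group are not told apart by this assay, even though the atoms are identical and only their connection differs. No supporting measurement is available that bears on this result.

On these data alone, whether an amine or a carboxylic acid in place of the trifluoromethyl group on this phenyl ring would give a step beyond the scatter remains open. As far as these compounds go, it is also open how a plain phenyl on the sulfonyl sulfur would compare with compound 3 and compound 4.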